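A few compounds are considered here, and "the series" means these few. Any claim that something is new, unique, unknown or untested is made for them only; others in the source may bear on it.

Notes on the series. Compound 1 `CC1=C(C(=O)OCC2CCN(C(=O)OC(C)(C)C)CC2)C(c2ccc3c(c2)OCCO3)C2=C(CC(C)(C)CC2=O)N1` gives 1520 nM in an assay on HEK293 cells for inhibition of neurogenic locus notch homolog protein 1 (Homo sapiens), read by a luciferase reporter and resazurin assay, with a stated time of 16 h; on this read-out higher numbers stand for weaker inhibition and lower numbers for stronger inhibition. Compound 2 `CC1=C(C(=O)OCC2CCN(C(=O)OC(C)(C)C)CC2)C(c2cc(Cl)cc(Cl)c2)C2=C(CC(C)(C)CC2=O)N1` gives 640 nM in this assay, the step being a 2.4-fold lower number from compound 1 to compound 2 (0.38 log units; beyond the scatter). Compound 3 `CC1=C(C(=O)OCC2CCN(C(=O)OC(C)(C)C)CC2)C(c2ccc(-c3ccccc3)cc2)C2=C(CC(C)(C)CC2=O)N1` returns only the limit of this assay, > 10000 nM, and so has no number of its own. The steps of an at least 6.5-fold higher number from compound 1 to compound 3 (0.81 log units; beyond the scatter) and an at least 15-fold higher number from compound 2 to compound 3 (1.19 log units; beyond the scatter) place compound 3 as the weakest of the three, and because of the limit of > 10000 nM in this assay, at which 1 of the 3 values shown sits, only a lower bound on the size of these steps is known.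

Compound 4 `CC1=C(C(=O)OCC2CCN(C(=O)OC(C)(C)C)CC2)C(c2ccc(Br)cc2F)C2=C(CC(C)(C)CC2=O)N1` differs from compound 3 by 4-bromo-2-fluorophenyl in place of 4-phenylphenyl on a saturated ring carbon. This runs opposite to the change of the step of an at least 15-fold higher number from compound 2 to compound 3 (1.19 log units; beyond the scatter), since the 3,5-dichlorophenyl of compound 2 is, like the incoming 4-bromo-2-fluorophenyl, a halogen-bearing single phenyl. A large fall is therefore expected for the step of an at least 11-fold lower number from compound 3 to compound 4 (1.04 log units; beyond the scatter), taking compound 4 well below the limit of compound 3. Compound 4 is estimated at 900 nM, within 300 nM to 3000 nM. That estimate sits close to the value of compound 2, 640 nM.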

Compound 4, half-maximal inhibitory concentration: > 10000 nM
Compound 4: a limit, no number (the forecaster's own chance of this, stated with the estimate: 5%); middle value at least 11-fold (1.04 log units) from the limit.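

Compound 2 and compound 4 both carry a halogen-bearing single phenyl on the saturated ring carbon, yet 4-bromo-2-fluorophenyl in place of 3,5-dichlorophenyl gives an at least 15-fold higher number from compound 2 to compound 4 (1.19 log units; beyond the scatter), so halogens on a single phenyl do not suffice at this position. The 2,3-dihydro-1,4-benzodioxin-6-yl of compound 1 also reads better than the 4-bromo-2-fluorophenyl, with an at least 6.5-fold higher number from compound 1 to compound 4 (0.81 log units; beyond the scatter), so replacing the 4-phenylphenyl of compound 3 with a single ring does not by itself restore a measurable value. The step from compound 3 to compound 4 cannot be read, and the other steps have only lower bounds on their size, because of the limit: the limit of > 10000 nM in this assay, at which 2 of the 4 values shown sit.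

Whether the bromine or the fluorine of 4-bromo-2-fluorophenyl accounts for the loss remains open. Also open, as far as these compounds go, is how a phenyl bearing an amine or a carboxylic acid would read at this place.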